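The source may hold more compounds than are shown below. What is called first, only, known or untested is meant among the compounds shown, and "the series" means these compounds.

Measured compounds:
Compound 1, `c1ccc(-c2ccncn2)c(OCC2=NCCN2)c1`: in a functional assay for activation of Alpha-1D adrenergic receptor (Homo sapiens), read by calcium flux (on this read-out lower numbers stand for an effect already at smaller amounts and higher numbers for an effect only at larger amounts of compound), compound 1 gives only a limit, < 100000 nM.
Compound 2, `c1ccc(-c2nccs2)c(OCC2=NCCN2)c1`: in this assay compound 2 gives 31.6 nM.

Compound 2 thus holds the only real number shown in this assay; the other entry is a limit, (the limit of < 100000 nM in this assay, at which 1 of the 2 values shown sits). Because of that limit, the step from compound 1 to compound 2 cannot be sized: a step that the limit leaves unreadable from compound 1 to compound 2.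

Compound 3, `Cc1ccc(-c2ccccc2OCC2=NCCN2)s1`, differs from compound 2 in one place: 5-methylthiophen-2-yl in place of 1,3-thiazol-2-yl on an aromatic carbon. No measured step speaks to this exchange, since the only step shown is unreadable. The expectation therefore rests on compound 2 alone, and the step from compound 2 to compound 3 is expected to be a 1.3-fold higher number from compound 2 to compound 3 (0.10 log units; within the scatter), with no direction claimed beyond the usual scatter. Compound 3 is accordingly estimated at 40 nM in this assay, with a range from 8 nM to 200 nM.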

Compound 3, half-maximal effective concentration: < 100000 nM
Compound 3: no number, only a limit; the forecaster's own chance of this, stated with the estimate: 5%; the middle value is on the limit's open side.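

In this assay compound 3 gives < 100000 nM as a limit and not a number. No new step can be read from compound 3 to compound 1 or compound 2: the limit of < 100000 nM in this assay, at which 2 of the 3 values shown sit. The compounds shown leave open how far compound 1 and compound 3 actually lie from compound 2.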